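The source may report more compounds than this note shows. Statements on the series, on what has been measured and on what is new or still open speak of the compounds shown alone.

Compound 2 `O=c1[nH]cnc2c1c(-c1ccsc1)cn2[C@@H]1O[C@H](CO)[C@@H](O)[C@H]1O` gives in a functional assay on K562 cells (Homo sapiens), read by MTT assay, with a stated time of 72 h (a higher number here means a weaker inhibitor, a lower number a stronger inhibitor), only a limit of the assay, > 20000 nM, so no numerical potency is known for it. The two other measured compounds stand at the same place. Compound 1 `Cc1ncnc2c1c(-c1cccs1)cn2[C@@H]1O[C@H](CO)[C@@H](O)[C@H]1O` gives in this assay the limit > 20000 nM. Compound 3 `Cc1ncnc2c1c(-c1ccoc1)cn2[C@@H]1O[C@H](CO)[C@@H](O)[C@H]1O` gives in this assay the limit > 20000 nM. All three measured values therefore sit at the ceiling of the measurement (the limit of > 20000 nM in this assay, at which 3 of the 3 values shown sit), and none of them is a readable number.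

Compound 4 `O=c1[nH]cnc2c1c(-c1ccoc1)cn2[C@@H]1O[C@H](CO)[C@@H](O)[C@H]1O` has not yet been measured. It differs from compound 2 in a single place:
furan-3-yl in place of thiophen-3-yl on an aromatic carbon

One measured step resembles this change: the step from compound 1 to compound 3, in which furan-3-yl takes the place of thiophen-2-yl, a step that the two limits leave unreadable from compound 1 to compound 3. Its size cannot be read; both of its ends are limits. Exchanging a thiophene for a furan thus left the measured compounds where they were, at a value the assay could not resolve.

With nothing in the measured set pointing toward a readable value, compound 4 is expected to give 30000 nM, with a plausible range from 10000 nM to 100000 nM. The expected step from compound 2 to compound 4, a step that the limit leaves unreadable from compound 2 to compound 4, is an estimate only, and most likely the assay will again report a limit rather than a number.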

Compound 4, half-maximal inhibitory concentration: 12500 nM
Estimate against measurement, compound 4: 2.4-fold (0.38 log units) above, within the range that was stated.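

In this assay, within the data shown here, furan-3-yl on this aromatic carbon gives compound 4 the only readable number so far, so a compound with a group at this position can come within range of the measurement. The exchange of thiophen-3-yl for furan-3-yl gives an at least 1.6-fold lower number from compound 2 to compound 4 (0.20 log units; that floor lies within the scatter), so this change cannot yet be called a real gain, although the true step may be larger than this floor. Furan-3-yl is not enough on its own: compound 3 carries the same group on a core that differs in one place from that of compound 4. Compound 3 gives > 20000 nM, which is a limit of the assay.

The step between the two limits of compound 1 and compound 3 cannot be read, so any difference between thiophen-2-yl and furan-3-yl on that core stays open, and most of this small set remains at the ceiling: the limit of > 20000 nM in this assay, at which 3 of the 4 values shown sit.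

Also open, going by these compounds, is whether a pyridin-3-yl ring, an amine or a longer alkyl chain at this same aromatic carbon would give a number clearly lower than that of compound 4, or return the compound to the limit.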